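The source may report more compounds than this note shows. Statements on the series, on what has been measured and on what is new or still open speak of the compounds shown alone.

Measured in a functional assay on HepG2 cells (Homo sapiens) for cytotoxicity, read by MTT assay, with a stated time of 48 h; on this read-out higher numbers stand for weaker inhibition and lower numbers for stronger inhibition:
compound 1 `COc1cc(/C=C/C(=O)/C=C(/C=C/c2ccc(O)c(OC)c2)NCCO)ccc1O`: > 100000 nM
compound 2 `COCCCN1C(/C=C/c2ccc(O)cc2)=CC(=O)CC1c1ccc(O)cc1`: > 100000 nM

Compound 1 gives only a limit, > 100000 nM, and not a number. Among the compounds with values here, the series so far shows (the limit of > 100000 nM in this assay, at which 2 of the 2 values shown sit), and no measured step is available.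

Compound 3 `COCCCNC(=C\C(=O)/C=C/c1ccc(O)c(OC)c1)/C=C/c1ccc(O)c(OC)c1` keeps the core of compound 1 and has methoxymethyl in place of hydroxy on a saturated chain carbon, two bonds along the chain from an amine nitrogen. This turns 2-hydroxyethyl into 3-methoxypropyl.

Compound 2, which also carries a 3-methoxypropyl chain, gives > 100000 nM, likewise a limit. The expectation of little change rests on this limit for compound 2. In this assay, only a small step toward stronger inhibition is expected, estimated as an at least 1.4-fold lower number from compound 1 to compound 3 (0.15 log units; that floor lies within the scatter). For compound 3 the estimated value is 70000 nM, with an expected range of 25000 nM to 120000 nM.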

Compound 3, half-maximal inhibitory concentration: > 100000 nM
Compound 3: a limit, no number; the forecaster's own chance of this, stated with the estimate: 60%; middle value at least 1.4-fold (0.15 log units) from the limit.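

Within the data shown here, compound 3, like compound 1, gives only a limit in this assay, so no step between compound 1 and compound 3 can be read. The compounds shown leave open whether 3-methoxypropyl in place of 2-hydroxyethyl changes inhibition in this assay at all.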